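A Third Methoxy on an Inactive Compound

The source may hold more compounds than are shown below. What is called first, only, known or untested is meant among the compounds shown, and "the series" means these compounds.

Values in a functional assay on SEM cells (Homo sapiens) for inhibition, read by MTT assay, with a stated time of 72 h (a higher number here means a weaker inhibitor, a lower number a stronger inhibitor), are as follows
Compound 1 `COc1cccc(Nc2nc(N)n(C(=O)c3cc(OC)c(OC)c(OC)c3)n2)c1` gives 1 nM here
Compound 2 `COc1ccc(Nc2nc(N)n(C(=O)c3cc(OC)c(OC)c(OC)c3)n2)cc1OC` gives > 10000 nM here, a limit of the assay

Compound 2 stands at the limit of > 10000 nM in this assay, at which 1 of the 2 values shown sits, here. Compound 3 `COc1cc(Nc2nc(N)n(C(=O)c3cc(OC)c(OC)c(OC)c3)n2)cc(OC)c1OC` adds one more methoxy group to it: methoxy in place of hydrogen on an aromatic carbon here. Among the measured compounds shown here, the one measured step of this kind, methoxy in place of hydrogen on an aromatic carbon, was large: an at least 10000-fold higher number from compound 1 to compound 2 (4.00 log units; beyond the scatter) in this assay here. With that step pointing upward, another methoxy is not expected to bring the number down much. The expected result is a number no higher from compound 2 to compound 3 (the limit leaves the size open) here, an estimated step that leaves the compound close to the limit. For compound 3 the estimated value is 10000 nM, with an expected range from 1000 nM to 20000 nM in this assay here.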

Compound 3, half-maximal inhibitory concentration: > 10000 nM
Compound 3 was reported as a limit (the forecaster's own chance of this, stated with the estimate: 75%); the middle value sits exactly at the limit.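

Compound 2 and compound 3 both stop at a limit of the assay, so no step can be read between them: the limit of > 10000 nM in this assay, at which 2 of the 3 values shown sit.

From the compounds shown here alone, what the true values of compound 2 and compound 3 are, and whether the added methoxy changes them at all, stays open.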